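Series notes: substituent on the chain carbon bound to the aromatic nitrogen

The source may hold more compounds than are shown below. What is called first, only, known or untested is meant among the compounds shown, and "the series" means these compounds.

Measured so far:
compound 1 `CCn1c(=O)n(C2OC(CO)[C@@H](O)[C@H]2O)c2nc(N)nc(O)c21`, 15 uM
compound 2 `C=CCn1c(=S)n(C2OC(CO)[C@@H](O)C(O)[C@H]2O)c2nc(N)nc(O)c21`, 1 uM
compound 3 `C=CCn1c(=S)n([C@@H]2O[C@H](CO)[C@H]3OC(C)(C)O[C@H]32)c2nc(N)nc(O)c21`, 55 uM

In a functional assay (B cells) with Mus musculus as the target (a lower number here means that less compound is needed, a higher number that more compound is needed for the effect), compound 1 stands second highest of the three numbers; compound 3 lies nearest, with a higher number beyond the scatter, and compound 2 furthest, with a lower number beyond the scatter. Compound 4 `COc1ccc(Cn2c(=O)n(C3OC(CO)[C@@H](O)[C@H]3O)c3nc(N)nc(O)c32)cc1` is not yet measured. It differs from compound 1 in one place: 4-methoxyphenyl in place of methyl on a saturated chain carbon bound to an aromatic nitrogen. No pair of measured compounds shares this change, so nothing shown here tells its size. A modest step is expected in this assay, more likely toward a lower number than a higher one, and possibly within the scatter. For compound 4 the estimate is 8 uM, with a range from 1.5 uM to 40 uM, which is expected to mean a step of a 1.9-fold lower number from compound 1 to compound 4 (0.27 log units; within the scatter).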

Compound 4, concentration for half-maximal effect: 135 uM
Compound 4: the middle estimate sits 17-fold (1.23 log units) below what was measured, outside the stated range (above it).
By their numbers in this assay, from the lowest: compound 2; then compound 1; then compound 3; then compound 4.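

In this assay, for the compounds shown here, 4-methoxyphenyl in place of methyl on a saturated chain carbon bound to an aromatic nitrogen gives a 9.0-fold higher number from compound 1 to compound 4 (0.95 log units; beyond the scatter) and so provides the first single-change reading at this position. On this core, the step from ethyl to 4-methoxybenzyl is therefore not tolerated without a cost in this assay. Nothing available bears on the cause of this step.

As far as these compounds go, whether the shift follows the aromatic ring or the methoxy group remains open. Plain benzyl, a longer chain such as butyl, or a chain ending in an amine would help separate these.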